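The compounds below may be only part of what the source reports. "The series", "measured", "known", "first", "only" and "open" are said of these compounds alone.

Measured compounds:
- compound 1, `Nc1ccccc1NC(=O)/C=C/c1ccc(Cn2cnc3c(Nc4cccc(Cl)c4)nc(Cl)nc32)cc1`: 15.8%
- compound 2, `CCCCn1cnc2c(Nc3ccccc3)nc(NCOCc3ccc(/C=C/C(=O)Nc4ccccc4N)cc3)nc21`: 51.9%
- compound 3, `Nc1ccccc1NC(=O)c1ccc(Cn2cnc3c(Nc4ccccc4)nc(Cl)nc32)cc1`: 83.5%

In a functional assay on HCT-116 cells (Homo sapiens) for antiproliferative activity, read by CCK-8 assay, with a stated time of 72 h, tested at 8 uM (on this read-out lower numbers stand for a weaker effect and higher numbers for a stronger effect at the one concentration tested), compound 1 gives 15.8%, the lowest of the three numbers. Compound 2 gives 51.9%, a number higher by more than the scatter, and compound 3 gives 83.5%, higher still and also beyond the scatter. Among the compounds with values here, no two measured compounds differ in only one place, so no single change has a known size in this set. Compound 4, `Nc1ccccc1NC(=O)/C=C/c1ccc(Cn2cnc3c(NCc4ccccc4)nc(Cl)nc32)cc1`, is not yet measured; it differs from compound 1 by benzyl in place of 3-chlorophenyl on a nitrogen on an aromatic ring. Within the data shown here, nothing among the measured compounds shows what this change does. The expected step is a number 9.2 percentage points higher from compound 1 to compound 4 (within the scatter), a small rise that may not clear the scatter. Compound 4 is estimated at 25%, with a range from 5% to 55%.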

Compound 4, a percentage reported as inhibition, at one concentration (the size of the read-out at that concentration, not a potency): 17.4%
Compound 4: middle estimate off by 7.6 percentage points, on the high side; measured number inside the range.
By their numbers in this assay, from the lowest: compounds 1 and 4 (each within the scatter of the next); then compound 2; then compound 3.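

In this assay, within the data shown here, the change from (3-chlorophenyl)amino to benzylamino gives a number 1.6 percentage points higher from compound 1 to compound 4 (within the scatter) and this is the first single change that can be read. At this nitrogen, this swap leaves the number within the scatter, although the chlorine goes and a carbon enters. Nothing measured here accounts for this result.

On these data alone, whether a smaller group such as methyl, or a chain ending in an amine, would move the number at this nitrogen stays open. So does whether the same swap would stay within the scatter on another core.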